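Chloro to Cyano on the Aryl Ring of Compound 1

This account rests on a few compounds, and the source may have more. Where it says the series, first, only, none or still open, it means among the compounds named here.

Three compounds sharing one core were tested in an ADME assay on J774 cells (Mus musculus) for cytotoxicity, read by MTT assay, with a stated time of 48 h, tested at 100 ug/mL; a higher number here means a weaker effect of the compound at the concentration tested, a lower number a stronger effect. Compound 1 `O=C(N/N=C/c1ccccc1Cl)c1cnccn1` gives 66%, the lowest of the three numbers. Compound 2 `O=C(N/N=C/c1ccc(Br)cc1)c1cnccn1` gives 100%, and compound 3 `CCOc1ccc(/C=N/NC(=O)c2cnccn2)cc1` gives 98%. Among the compounds with values here, the single measured step between compounds differing in one place, a number 2 percentage points lower from compound 2 to compound 3 (within the scatter), lies within the scatter, so compound 2 and compound 3 cannot be ordered. Compound 1 stands beyond the scatter below each of them, and it is the compound from which the next step is taken.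

Compound 4 `N#Cc1ccccc1/C=N/NC(=O)c1cnccn1` differs from compound 1 by one change: cyano in place of chloro on an aromatic carbon. Within the data shown here, no measured step bears on a change at this position; the only measured step concerns a different position on the same ring and was within the scatter, so it offers no guide to the size or direction of the present step. Compound 4 is therefore expected to remain close to compound 1, with an estimated step of a number 10 percentage points higher from compound 1 to compound 4 (within the scatter) and wide uncertainty. The estimate for compound 4 in this assay is 76%, with an expected range from 55% to 100%.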

Compound 4, a percentage reported as activity, at one concentration (the size of the read-out at that concentration, not a potency): 75%
Estimate against measurement, compound 4: 1 percentage points above, and the stated range covers the measured number.
By their numbers in this assay, from the lowest: compounds 1 and 4 (each within the scatter of the next); then compounds 3 and 2 (each within the scatter of the next).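

At this position, ortho to a large group, the first step measured on the ring is a number 9 percentage points higher from compound 1 to compound 4 (within the scatter) in this assay. The chloro can therefore give way to a cyano, which brings a triple bond and a hydrogen-bond acceptor, without a change in this read-out that can be told from the usual scatter, and compound 1 and compound 4 cannot be ordered. Nothing measured here bears on why the two compounds read alike.

What the compounds shown leave open is whether any group at this place moves the number beyond the scatter, for instance an amine, a carboxylic acid or a longer chain such as an ethoxy. They also leave open whether a bromo here would read like the chloro and the cyano.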